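One Fluorine Added: Expected Effect on Plasma Free Fraction

The compounds below may be only part of what the source reports. "The series", "measured", "known", "first", "only" and "open" are said of these compounds alone.

Measured compounds:
compound 1, `CCCS(=O)(=O)c1cccc(C#Cc2cc(Cl)ccc2OCC(=O)O)c1`: 0.008
compound 2, `CC(C)S(=O)(=O)c1ccc(Cl)c(C#Cc2cc(Cl)ccc2OCC(=O)O)c1`: "not determined" (no result reported)

In an ADME assay on a cell-free system (plasma, Homo sapiens) (on this read-out lower numbers stand for a smaller free fraction and higher numbers for a larger free fraction), compound 1 gives 0.008. Compound 2 was part of the same study, but in this assay compound 2 gives "not determined" (no result reported); its entry carries no number. Going by the values given here, compound 1 therefore stands alone: it holds the only number in this assay, and the one further entry carries no value. Among the compounds with values here, with no second measured compound, no step between measured compounds can be drawn, and nothing about the assay's behaviour toward structural change can be read from the data themselves.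

The unmeasured compound 3, `CCCS(=O)(=O)c1ccc(F)c(C#Cc2cc(Cl)ccc2OCC(=O)O)c1`, differs from compound 1 by fluoro in place of hydrogen on an aromatic carbon. Everything else in the shared core of compound 1, the alkyne link and the acid-bearing ring, is kept.

Because compound 1 gives 0.008, the expectation for compound 3 starts from that figure. The expected step of a 1.3-fold lower number from compound 1 to compound 3 (0.12 log units; within the scatter) is small, at most a slight move toward a smaller free fraction, lying within the usual scatter. Compound 3 is thus expected to give 0.006, with a range from 0.003 to 0.012.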

Compound 3, unbound fraction: 0.01
Estimate against measurement, compound 3: 1.7-fold (0.22 log units) below; measured number inside the range.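

In this assay, going by these compounds alone, fluoro in place of hydrogen on an aromatic carbon, ortho to a large group and para to a propylsulfonyl group, gives a 1.3-fold higher number from compound 1 to compound 3 (0.10 log units; within the scatter), and this is the first step that can be read at all. At this position, then, this single replacement leaves compound 3 indistinguishable from compound 1 on this read-out, which the lone earlier number could not show. The data offer no measured property that bears on this outcome.

The compounds shown leave open whether a methoxy group, a trifluoromethyl group or an amine at this same position would also stay within the scatter, and whether fluoro on another aromatic carbon would behave as it does here. Steps involving compound 2 cannot be read, as its entry carries no number, so the free fraction also remains unknown for any change to the propylsulfonyl chain or for replacing the carboxylic acid with an amide.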